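Bromo to Trifluoromethyl on the Shared Core

The source may hold more compounds than are shown below. What is called first, only, known or untested is meant among the compounds shown, and "the series" means these compounds.

Measured compounds:
compound 1, `Cc1ccc(C(=O)NN2C(=O)NC3(CC3(C)C)C2=O)cc1`, 300 mg/kg
compound 2, `CC1(C)CC12NC(=O)N(NC(=O)c1ccc(Br)cc1)C2=O`, 300 mg/kg

In a functional assay on the whole organism for inhibition, with Mus musculus as the target, with a stated time of 4 h (a higher number here means that more compound is needed for the effect, a lower number that less compound is needed), compound 1 gives 300 mg/kg. Compound 2 stands level with it at the digits shown, since the step of no change at the digits printed from compound 1 to compound 2 (within the scatter) lies within the scatter. The change that leads on to compound 3, `CC1(C)CC12NC(=O)N(NC(=O)c1ccc(C(F)(F)F)cc1)C2=O`, is trifluoromethyl in place of bromo on an aromatic carbon. For the measured compounds named here, the only measured step that bears on it, the exchange of one group on the same aromatic carbon, is no change at the digits printed from compound 1 to compound 2 (within the scatter), which was flat. Nothing in the data separates these groups on this aromatic carbon in this assay, so no step beyond the scatter is expected; the estimated step is no change at the digits printed from compound 2 to compound 3 (within the scatter). Compound 3 is therefore expected to give 300 mg/kg in this assay, with a range from 150 mg/kg to 600 mg/kg.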

Compound 3, minimum effective dose: 300 mg/kg
The estimate for compound 3 equals the measured number at the digits printed; low and high end bracket the measured number.
By their numbers in this assay, from the lowest: compounds 1, 2 and 3 (each within the scatter of the next).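

In this assay the step of no change at the digits printed from compound 2 to compound 3 (within the scatter) is a second flat exchange on this aromatic carbon, and here the entering trifluoromethyl has 4 heavy atoms where the leaving bromo has 1 heavy atom. The step of no change at the digits printed from compound 1 to compound 3 (within the scatter) links the two ends of the set, so methyl, bromo and trifluoromethyl, para to a large group, cannot be told apart in this assay, and the change in heavy atoms leaves the read-out where it was. No measurement is available that would account for this flat result.

From the compounds shown here alone, all three compounds sit at one value, so it remains open whether any group on this carbon can move the minimum effective dose. An amine, a carboxylic acid or a longer chain in this place might behave differently, and the compounds shown do not tell.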